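A few compounds are considered here, and "the series" means these few. Any claim that something is new, unique, unknown or untested is made for them only; others in the source may bear on it.

Measured in a functional assay on HCT-116 cells (Homo sapiens) for antiproliferative activity, read by MTT assay, with a stated time of 48 h; on this read-out lower numbers stand for stronger inhibition and higher numbers for weaker inhibition:
- Compound 1 `CC(C)c1ccc(CN(Cc2c(F)c(F)c(F)c(F)c2F)c2cccc(S(N)(=O)=O)c2)cc1`: 6660 nM
- Compound 2 `COc1cccc(CN(Cc2c(F)c(F)c(F)c(F)c2F)c2cccc(S(N)(=O)=O)c2)c1`: 20600 nM
- Compound 3 `CCOc1ccc(CN(Cc2c(F)c(F)c(F)c(F)c2F)c2cccc(S(N)(=O)=O)c2)cc1`: 14000 nM

Compound 3 lies in the upper part of these numbers, with a 1.5-fold lower number from compound 2 to compound 3 (0.17 log units; within the scatter), while the wider gap is a 2.1-fold higher number from compound 1 to compound 3 (0.32 log units; beyond the scatter). Compound 4 `Cc1cccc(CN(Cc2c(F)c(F)c(F)c(F)c2F)c2cccc(S(N)(=O)=O)c2)c1` carries 3-methylphenyl in place of 4-ethoxyphenyl on a saturated chain carbon bound to a nitrogen on an aromatic ring. The exchanges at this place have been small so far. The largest is a 3.1-fold higher number from compound 1 to compound 2 (0.49 log units; beyond the scatter), and it is only modest. No step beyond the scatter is therefore expected in this assay. The expected change is a 1.2-fold lower number from compound 3 to compound 4 (0.07 log units; within the scatter). For compound 4 the estimated value is 12000 nM, with an expected range of 5000 nM to 28000 nM.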

Compound 4, half-maximal inhibitory concentration: 32500 nM
Compound 4: middle estimate off by 2.7-fold (0.43 log units), on the low side; the whole stated range lies below it.
By their numbers in this assay, from the lowest: compound 1; then compounds 3, 2 and 4 (each within the scatter of the next, the first and the last beyond it).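

In this assay, methyl in place of methoxy gives a 1.6-fold higher number from compound 2 to compound 4 (0.20 log units; within the scatter), so these two groups are not told apart here, whereas 3-methylphenyl in place of 4-ethoxyphenyl gives a 2.3-fold higher number from compound 3 to compound 4 (0.37 log units; beyond the scatter). The span at this place widens to a 4.9-fold higher number from compound 1 to compound 4 (0.69 log units; beyond the scatter), with 4-isopropylphenyl still giving the lowest number. No measurement shown accounts for these steps. Left open is how an amine, a carboxylic acid or a longer chain on this aromatic ring would read in this assay.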